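The compounds below may be only part of what the source reports. "The series", "measured", "known", "first", "only" and "open" are said of these compounds alone.

Measured compounds in a functional assay on HT-29 cells (Homo sapiens) for cytotoxicity, read by MTT assay, with a stated time of 72 h; on this read-out lower numbers stand for stronger inhibition of growth and higher numbers for weaker inhibition of growth:
compound 1, `CS/C(=N\C(=O)c1csc([N+](=O)[O-])c1)NC(=O)c1csc([N+](=O)[O-])c1`, 51800 nM
compound 2, `C[Se]/C(=N\C(=O)c1ccno1)NC(=O)c1ccno1`, 0.79 nM
compound 3, `CS/C(=N\C(=O)c1cc(-c2ccccc2)nc2ccccc12)NC(=O)c1cc(-c2ccccc2)nc2ccccc12`, 23700 nM

Compound 1 gives the highest number of the three in this assay. Compound 3 comes nearest to it, with its 23700 nM lying below compound 1 by a gap beyond the scatter, while compound 2 at 0.79 nM sits far below both. Compound 2 carries a selenium group where compounds 1 and 3 carry methylsulfanyl, but it also differs in both acyl rings, so the numbers alone do not separate the two changes.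

Compound 4, `O=C(/N=C(/NC(=O)c1csc([N+](=O)[O-])c1)[Se]Cc1ccccc1)c1csc([N+](=O)[O-])c1`, is the next compound to be measured in this assay. It keeps the core of compound 1 and alters one group: a group of 8 heavy atoms (7 carbon, 1 selenium; one six-membered aromatic ring of carbon only) in place of a group of 2 heavy atoms (1 carbon, 1 sulfur; no ring), on a carbon with a double bond to nitrogen. Among the measured compounds shown here, no two measured compounds differ in just this way, so the size of the step has no direct precedent. Given that the only selenium-bearing compound, compound 2, gives 0.79 nM, a step toward lower numbers is expected, though the acyl rings of compound 2 are unrelated and the uncertainty is wide. The expected step of a 6.5-fold lower number from compound 1 to compound 4 (0.81 log units; beyond the scatter) is taken as a moderate gain beyond the scatter. Compound 4 is estimated at 8000 nM, in a range from 800 nM to 50000 nM.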

Compound 4, concentration for 50% growth inhibition: 9250 nM
Compound 4: the middle estimate sits 1.2-fold (0.06 log units) below what was measured; low and high end bracket the measured number.
By their numbers in this assay, from the lowest: compound 2; then compound 4; then compound 3; then compound 1.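

In this assay, among the compounds shown here, the change on the carbon with a double bond to nitrogen gives a 5.6-fold lower number from compound 1 to compound 4 (0.75 log units; beyond the scatter), the first step that can be read at a single place. It shows that this position accepts a group of 8 heavy atoms with a six-membered aromatic ring in place of methylsulfanyl, and that the number moves toward stronger inhibition of growth, not weaker, while the core of compound 1 stays unchanged. Nothing shown gives a reason for this step.

The step combines two changes, selenium for sulfur and the added aromatic ring, so its size cannot be assigned to either one; a benzyl group on sulfur or an ethyl chain on selenium, on the same core, would separate them. Going by these compounds, whether the same exchange gives a step of similar size with other acyl rings also remains open, since compound 2 and compound 3 each differ from compound 4 in more than one place.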